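This account rests on a few compounds, and the source may have more. Where it says the series, first, only, none or still open, it means among the compounds named here.

Measured so far:
compound 1, `ClCc1ccc(Cn2cnc3c(Cl)ncnc32)cc1` — 7410 nM
compound 2, `ClCc1cccc(Cn2cnc3c(Cl)nc(Cl)nc32)c1` — 5620 nM

In a functional assay on U-251 cells (Homo sapiens) for cytotoxicity, read by sulforhodamine B assay, with a stated time of 48 h (on this read-out higher numbers stand for lower toxicity in this test and lower numbers for higher toxicity in this test), compound 1 gives 7410 nM. Compound 2 gives 5620 nM in this assay. Compound 1 holds the top entry of the two numbers shown, but the gap to compound 2 lies within the scatter, so the two cannot be told apart on this read-out. Going by the values given here, no step between the measured compounds is available, because the two differ in more than one place.

Compound 3, `Nc1nc(Cl)c2ncn(Cc3ccc(CCl)cc3)c2n1`, is not yet measured in this assay. Relative to compound 1 the change is amino in place of hydrogen on an aromatic carbon. Among the compounds with values here, with no measured single-point step, there is nothing to fix the direction or size of this change; the working assumption is a step of no more than the scatter in either direction.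

Compound 3 is therefore expected at about 6500 nM in this assay, with a range from 2500 nM to 17000 nM. This estimate means an expected step of a 1.1-fold lower number from compound 1 to compound 3 (0.06 log units; within the scatter), which is expected to stay within the scatter.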

Compound 3, concentration lethal to 50% of the cells: 44700 nM
Beside the measured number, compound 3's estimate is 6.9-fold (0.84 log units) below it, outside the stated range (above it).
By their numbers in this assay, from the lowest: compounds 2 and 1 (each within the scatter of the next); then compound 3.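

In this assay, the series gains its first readable single-place step, a 6.0-fold higher number from compound 1 to compound 3 (0.78 log units; beyond the scatter), and it shows that this aromatic carbon, between two ring nitrogen atoms, is not indifferent to substitution: amino in place of hydrogen moves the read-out towards lower toxicity in this test. Going by these compounds alone, until now, the only comparison available was between compound 1 and compound 2, which differ in more than one place and lie within the scatter of each other, so neither this position nor this change could be read on its own. The step is a single observation from one pair, and no measurement shown here accounts for it.

As far as these compounds go, whether the shift is specific to amino or would also appear with methylamino, dimethylamino, hydroxy or methoxy on the same carbon remains open. Also open, from the compounds shown here alone, is whether amino would give a step of similar size on a compound with the other features of compound 2, as a single pair cannot show how far this change carries across the series.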